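The compounds below may be only part of what the source reports. "The series", "measured", "known", "first", "only" and "open" are said of these compounds alone.

Compound 2 `O=C(Nc1ccc(Cl)cc1)N1CCC[C@H]1c1nc(-c2ccccc2F)no1` is the starting point. In an ADME assay on MCF-10A cells (Homo sapiens) for inhibition, with a stated time of 48 h (on this read-out higher numbers stand for weaker inhibition and lower numbers for stronger inhibition), compound 2 gives only a limit of the assay, > 50000 nM. Compound 1 `O=C(Nc1ccc(OC(F)(F)F)cc1)N1CCC[C@H]1c1nc(-c2ccccc2)no1` likewise gives only a limit, > 50000 nM. Compound 3 `O=C(Nc1ccc(Cl)cc1)N1CCC[C@H]1c1nc(-c2ccccc2Cl)no1` also gives only a limit, > 50000 nM. Among the compounds with values here, the one measured step, a step that the two limits leave unreadable from compound 2 to compound 3, has no readable size because the limit of > 50000 nM in this assay, at which 3 of the 3 values shown sit, shows all three values sit at that limit. Compound 4 `Cc1ccc(-c2noc([C@@H]3CCCN3C(=O)Nc3ccc(Cl)cc3)n2)cc1` differs from compound 2 by 4-methylphenyl in place of 2-fluorophenyl on an aromatic carbon. Within the data shown here, no measured step with a readable size bears on this change, so neither a size nor a direction can be taken from the data, and compound 4 is expected to remain at the limit as well. The expected step that the limit leaves unreadable from compound 2 to compound 4 is accordingly close to nothing. Compound 4 is estimated at 60000 nM, within a range from 20000 nM to 200000 nM.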

Compound 4, half-maximal inhibitory concentration: > 50000 nM
Compound 4 gave a limit, no number (the forecaster's own chance of this, stated with the estimate: 85%); the middle value lies beyond the limit too.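

Compound 4, like compound 2 and compound 3, gives only a limit, so the steps among them cannot be read: the limit of > 50000 nM in this assay, at which 4 of the 4 values shown sit. The compounds shown leave open which structural change, if any, would give a readable number in this assay.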